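Methoxy to trifluoromethyl on the aromatic carbon

This account rests on a few compounds, and the source may have more. Where it says the series, first, only, none or still open, it means among the compounds named here.

Compound 1 `Cc1cccc(C(=O)N2CCn3nc(-c4ccc(F)cn4)cc3C2)c1` gives 150 nM in a functional assay on HEK293 cells for negative allosteric modulation of metabotropic glutamate receptor 5 (Homo sapiens), read by calcium flux, with a stated time of 20 min; a higher number here means a weaker inhibitor, a lower number a stronger inhibitor. For the measured compounds named here, compound 2 `COc1cccc(C(=O)N2CCn3nc(-c4ccc(F)cn4)cc3C2)c1` gives 482 nM in this assay, the higher of the two numbers so far, with the sole measured step being a 3.2-fold higher number from compound 1 to compound 2 (0.51 log units; beyond the scatter). Compound 3 `O=C(c1cccc(C(F)(F)F)c1)N1CCn2nc(-c3ccc(F)cn3)cc2C1` carries the change (trifluoromethyl in place of methoxy on an aromatic carbon). Going by the values given here, that step bears on it only loosely: methoxy leaves in both cases, but here a different group enters, and no measured step covers trifluoromethyl. Compound 3 is therefore expected to show a step of a 2.4-fold lower number from compound 2 to compound 3 (0.38 log units; beyond the scatter) toward a lower number, roughly back into the region of compound 1. The estimate for compound 3 is 200 nM, with a range of 60 nM to 700 nM.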

Compound 3, half-maximal inhibitory concentration: 383 nM
Compound 3: middle estimate off by 1.9-fold (0.28 log units), on the low side; the range from low to high includes it.
By their numbers in this assay, from the lowest: compound 1; then compounds 3 and 2 (each within the scatter of the next).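

In this position, trifluoromethyl and methoxy cannot be separated (a 1.3-fold lower number from compound 2 to compound 3 (0.10 log units; within the scatter)) in this assay. Methyl is the only one of the three groups that stands apart, since trifluoromethyl (a 2.6-fold higher number from compound 1 to compound 3 (0.41 log units; beyond the scatter)) and methoxy (a 3.2-fold higher number from compound 1 to compound 2 (0.51 log units; beyond the scatter)) both give higher numbers than it does. No available evidence explains this pattern.

On these data alone, whether a chlorine, a nitrile or an amine on this aromatic carbon would give a number lower than that of compound 1 remains open. Also open, as far as these compounds go, is how a longer chain such as ethyl would compare with methyl here.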